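A few compounds are considered here, and "the series" means these few. Any claim that something is new, unique, unknown or untested is made for them only; others in the source may bear on it.

Compound 1, `COc1cc(N(CC2CC2)c2cccc(C(F)(F)F)c2)cnc1C(=O)[C@H]1C[C@@H]1C(=O)O`, gives in an assay for inhibition of leukotriene C4 synthase (Homo sapiens), read by LC-MS, with stated times of 15 min and 30 min (on this read-out higher numbers stand for weaker inhibition and lower numbers for stronger inhibition), a value of 6.42 nM.
Compound 2, `COc1cc(N(CC(C)(C)O)c2cccc(C(F)(F)F)c2)cnc1C(=O)[C@H]1C[C@@H]1C(=O)O`, gives in this assay a value of 31.8 nM.
Compound 3, `CCN(c1cccc(C(F)(F)F)c1)c1cnc(C(=O)[C@H]2C[C@@H]2C(=O)O)c(OC)c1`, gives in this assay a value of 13 nM.

All three share one core and differ only in the group on the saturated chain carbon bound to a nitrogen on an aromatic ring. Going by the values given here, on the numbers so far compound 3 stands second highest of the three: a 2.0-fold higher number from compound 1 to compound 3 (0.31 log units; beyond the scatter), while a 2.4-fold lower number from compound 2 to compound 3 (0.39 log units; beyond the scatter).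

Compound 4, `COc1cc(N(Cc2ccc(F)cc2)c2cccc(C(F)(F)F)c2)cnc1C(=O)[C@H]1C[C@@H]1C(=O)O`, has not yet been measured in this assay. It differs from compound 3 by 4-fluorophenyl in place of methyl on a saturated chain carbon bound to a nitrogen on an aromatic ring.

The measured steps that bear on this are those at the same position: a 2.0-fold higher number from compound 1 to compound 3 (0.31 log units; beyond the scatter) and a 5.0-fold higher number from compound 1 to compound 2 (0.69 log units; beyond the scatter). Both are modest, and the swap to a cyclopropyl, which is the only ring among the measured groups, went toward a lower number. Among the compounds with values here, no measured step puts an aromatic ring at this position, so the guidance is indirect. A modest step toward a lower number is expected, a 1.6-fold lower number from compound 3 to compound 4 (0.21 log units; within the scatter), by analogy to the cyclopropyl case, though a wide range must be allowed. Compound 4 is therefore estimated at 8 nM in this assay, with a range from 3 nM to 25 nM.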

Compound 4, half-maximal inhibitory concentration in the leukotriene C4 synthase assay: 13.5 nM
For compound 4 the middle estimate is 1.7-fold (0.23 log units) below the measured one; low and high end bracket the measured number.
By their numbers in the leukotriene C4 synthase assay, from the lowest: compound 1; then compounds 3 and 4 (each within the scatter of the next); then compound 2.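

Going by these compounds alone, in the leukotriene C4 synthase assay the 4-fluorophenyl group, with 7 heavy atoms against 1 for methyl, leaves the number unmoved (a 1.0-fold higher number from compound 3 to compound 4 (0.02 log units; within the scatter)), so this position accepts an aromatic ring, which the earlier compounds could not show. In the leukotriene C4 synthase assay an aromatic ring here does not reach the number given by cyclopropyl (a 2.1-fold higher number from compound 1 to compound 4 (0.32 log units; beyond the scatter)), though it gives a lower number than 1-hydroxy-1-methylethyl (a 2.4-fold lower number from compound 2 to compound 4 (0.37 log units; beyond the scatter)). In a physicochemical assay for lipophilicity, read by LC-MS, in phosphate buffer, measured as octanol-water partition, at pH 7.4 (on this read-out lower numbers stand for lower lipophilicity and higher numbers for higher lipophilicity), compound 3 gives 0.7 and compound 4 gives 1.9. The same change is far from silent in the physicochemical assay and a large gain in measured lipophilicity here brought no gain in inhibition: the measured distribution coefficient of compound 3, 0.7, and of compound 4, 1.9, a number 1.20 log units higher (beyond the scatter).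

On these data alone, whether a plain phenyl would read the same as 4-fluorophenyl in the leukotriene C4 synthase assay remains open, so the fluorine's share in this result cannot be told. Also open, as far as these compounds go, is whether a benzyl ring carrying an amine or a carboxylic acid, or a longer chain ending in a cyclopropyl ring, would keep inhibition in the leukotriene C4 synthase assay while bringing the distribution coefficient back down.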